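Swapping Fluoro for Chloro on a Weak Hepatoma Inhibitor

This account rests on a few compounds, and the source may have more. Where it says the series, first, only, none or still open, it means among the compounds named here.

Compound 1 `CC(C)[C@H](Nc1ncnc2[nH]cnc12)c1nn(-c2cccnc2)c2cc(F)ccc12` — in a functional assay on Hep 3B2 cells (Homo sapiens) for inhibition, read by sulforhodamine B assay, with a stated time of 72 h (a lower number here means a stronger inhibitor, a higher number a weaker inhibitor), compound 1 gives only a limit, > 40000 nM.
Compound 2 `C[C@H](Nc1ncnc2[nH]cnc12)c1nn(-c2cccc(S(C)(=O)=O)c2)c2cc(F)ccc12` — compound 2 gives 13000 nM.
Compound 3 `C[C@H](Nc1nc(N)nc(N)c1C#N)c1nn(-c2cccc(S(C)(=O)=O)c2)c2cc(F)ccc12` — compound 3 gives 19700 nM.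

Compound 3 holds the highest of the two numbers shown, though the step of a 1.5-fold higher number from compound 2 to compound 3 (0.18 log units; within the scatter) stays within the scatter. Compound 1 sits at the limit of > 40000 nM in this assay, at which 1 of the 3 values shown sits.

Compound 4 `C[C@H](Nc1nc(N)nc(N)c1C#N)c1nn(-c2cccc(S(C)(=O)=O)c2)c2cc(Cl)ccc12` differs from compound 3 by chloro in place of fluoro on an aromatic carbon. For the measured compounds named here, no measured step changes a halogen on that ring; the only step measured, a 1.5-fold higher number from compound 2 to compound 3 (0.18 log units; within the scatter), changes another part of the molecule and stays within the scatter. For compound 4 the expected step is therefore small, a 1.3-fold lower number from compound 3 to compound 4 (0.12 log units; within the scatter). Compound 4 is expected to give 15000 nM, with a range from 6000 nM to 40000 nM.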

Compound 4, half-maximal inhibitory concentration: 5110 nM
The estimate for compound 4 lay 2.9-fold (0.47 log units) above the measured number; measured number outside the range, below it.
By their numbers in this assay, from the lowest: compound 4; then compounds 2 and 3 (each within the scatter of the next). At a limit, above all of these: compound 1.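

This position on the shared core responds to a single-atom change: in this assay, chloro in place of fluoro gives a 3.9-fold lower number from compound 3 to compound 4 (0.59 log units; beyond the scatter). It is the first step shown that lies beyond the scatter, so this aromatic carbon matters more to the reading than the earlier exchange on the amine nitrogen suggested. Nothing measured here accounts for the gain.

Going by these compounds, whether bromo or methyl on this carbon would lower the number further remains open. So does whether chloro would bring a similar gain on compound 2.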